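The source may report more compounds than this note shows. Statements on the series, on what has been measured and on what is new or still open speak of the compounds shown alone.

Measured so far: compound 1 `N[C@@H](C(=O)O)[C@@H]1CC(O)=NO1` with > 1000000 nM; compound 2 `NC(C(=O)O)C1CC(O)=NO1` with > 1000000 nM; 100000 nM; 100000 nM (3 entries).

In a functional assay on CHO cells with metabotropic glutamate receptor 2 (Rattus norvegicus) as the target, read by cAMP accumulation (a lower number here means that less compound is needed, a higher number that more compound is needed for the effect), compound 1 gives only a limit, > 1000000 nM. Compound 2 gives > 1000000 nM; 100000 nM; 100000 nM (3 entries). So compound 1 stands at the limit, with no number of its own. Compound 3 `N[C@H](C(=O)O)[C@@H]1CC(O)=NO1` is not yet measured and differs from compound 1 as follows: the two compounds have the same atoms and bonds and differ only in configuration as drawn: 1 of 2 stereo elements differ; a stereocentre at a saturated chain carbon is drawn R in compound 1 and S in compound 3. Because compound 2 is drawn without a defined configuration at that place the fact that one of compounds 1 and 2 is drawn with a defined configuration and the other without, at the place where they differ and two of its entries give a number (the several entries of compound 2 in this assay, > 1000000 nM; 100000 nM; 100000 nM (3 entries)), the expected step is an at least 10-fold lower number from compound 1 to compound 3 (1.00 log units; beyond the scatter), toward less compound needed. Compound 3 is estimated at 100000 nM, between 20000 nM and 1000000 nM.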

Compound 3, half-maximal effective concentration: > 1000000 nM
Compound 3 was reported as a limit; the forecaster's own chance of this, stated with the estimate: 35%; middle value at least 10-fold (1.00 log units) from the limit.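

Among the compounds shown here, compound 1 and compound 3 are each reported only as a limit, so no step between them can be read. The compounds shown leave open whether the configuration at this stereocentre changes how much compound is needed.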